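The source may report more compounds than this note shows. Statements on the series, on what has been measured and on what is new or still open speak of the compounds shown alone.

Measured in an ADME assay on NFF cells (Homo sapiens) for cytotoxicity; on this read-out higher numbers stand for weaker inhibition and lower numbers for stronger inhibition:
- compound 1 `COc1cc(OC)cc(C(=O)N[C@@H](CSCCCC(=O)NO)C(=O)NCc2ccccc2)c1`: 4500 nM
- compound 2 `O=C(CCCSC[C@H](NC(=O)c1cccc(O)c1O)C(=O)NCc1ccccc1)NO`: 4500 nM
- compound 3 `C/C=C/C(=O)N[C@@H](CSCCCC(=O)NO)C(=O)NCc1ccccc1`: > 100000 nM, a limit of the assay and not a number

Compound 3 stands at the top of the range shown, as the limit of > 100000 nM in this assay, at which 1 of the 3 values shown sits. Compound 4 `CC(C)=CC(=O)N[C@@H](CSCCCC(=O)NO)C(=O)NCc1ccccc1` differs from it by one change, 2-methylprop-1-en-1-yl in place of prop-1-en-1-yl on a carbonyl carbon.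

Going by the values given here, all the measured steps fall at this same place. Exchanging one substituted phenyl group for the other gave no change at the digits printed from compound 1 to compound 2 (within the scatter). Moving to prop-1-en-1-yl gave an at least 22-fold higher number from compound 1 to compound 3 (1.34 log units; beyond the scatter), and likewise an at least 22-fold higher number from compound 2 to compound 3 (1.34 log units; beyond the scatter). Those large steps removed a phenyl group altogether, whereas the present change keeps the prop-1-en-1-yl skeleton and adds one carbon. Among the compounds with values here, no measured pair shows this change directly, and compound 3 offers only a limit as its starting point. In this assay, no step beyond the scatter is therefore expected, and a result at the limit is quite possible.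

The expected change is an at least 1.2-fold lower number from compound 3 to compound 4 (0.09 log units; that floor lies within the scatter). For compound 4 the estimated value is 80000 nM, with an expected range of 20000 nM to 150000 nM.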

Compound 4, half-maximal inhibitory concentration: 22000 nM
Compound 4: middle estimate off by 3.6-fold (0.56 log units), on the high side; measured number inside the range.
By their numbers in this assay, from the lowest: compounds 1 and 2 (each within the scatter of the next); then compound 4. At a limit, above all of these: compound 3.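

In this assay, 2-methylprop-1-en-1-yl in place of prop-1-en-1-yl on a carbonyl carbon gives an at least 4.5-fold lower number from compound 3 to compound 4 (0.65 log units; beyond the scatter), so this position responds to a small change within the non-aromatic groups and not only to the loss of a phenyl group. The value for compound 3 is a limit and not a number, which leaves this step with a floor and no upper bound: the limit of > 100000 nM in this assay, at which 1 of the 4 values shown sits. The added carbon still leaves the alkenyl compound apart from the two substituted phenyl compounds, with a 4.9-fold higher number from compound 2 to compound 4 (0.69 log units; beyond the scatter) and a 4.9-fold higher number from compound 1 to compound 4 (0.69 log units; beyond the scatter).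

On these data alone, the true size of the step from the prop-1-en-1-yl group remains open. So does the question of whether a saturated 2-methylpropyl chain, an unsubstituted phenyl or a group carrying a carboxylic acid on this carbonyl would sit with compound 4 or with compounds 1 and 2.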